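A few compounds are considered here, and "the series" means these few. Any claim that something is new, unique, unknown or untested is made for them only; others in the source may bear on it.

In a physicochemical assay for solubility, read by HPLC, in phosphate buffer, with a stated time of 16 h, at pH 6.8 (on this read-out higher numbers stand for higher solubility and lower numbers for lower solubility), compound 1 `Cc1ccc([C@H](C)NC(=O)Cn2nnc3ccccc3c2=O)cc1` gives 12000 nM, compound 2 `COc1ccc([C@H](C)NC(=O)Cn2nnc3ccccc3c2=O)cc1` gives 15000 nM and compound 3 `Cc1ccc([C@H](C)NC(=O)Cn2nnc3ccccc3c2=O)cn1` gives 9800 nM. Compound 1 therefore stands within the scatter of the other two, and the three cannot be ranked. Compound 4 `COc1cccc2nnn(CC(=O)N[C@@H](C)c3ccc(C)cc3)c(=O)c12` differs from compound 1 on the shared core: methoxy in place of hydrogen on an aromatic carbon. Within the data shown here, no measured step changes the core itself, so the evidence is indirect. The closest case is a 1.3-fold higher number from compound 1 to compound 2 (0.10 log units; within the scatter), which also introduces methoxy, in place of methyl. The other is a 1.2-fold lower number from compound 1 to compound 3 (0.09 log units; within the scatter). Both stay within the scatter, so no larger change is expected here. The expected step is a 1.2-fold lower number from compound 1 to compound 4 (0.08 log units; within the scatter). For compound 4 the estimate is 10000 nM, with an expected range of 4000 nM to 22000 nM.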

Compound 4, solubility: 9300 nM
Estimate against measurement, compound 4: 1.1-fold (0.03 log units) above; the measured number falls inside the stated range.
By their numbers in this assay, from the lowest: compounds 4, 3, 1 and 2 (each within the scatter of the next).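

Compound 4 is the first shown with a change on the shared core itself, a methoxy on an aromatic carbon ortho to a fused ring and meta to a fused ring. In this assay this gives a 1.3-fold lower number from compound 1 to compound 4 (0.11 log units; within the scatter) so this added group leaves the number indistinguishable from that of compound 1. No measurement shown offers an explanation for this step. Still open, on these data alone, is whether an amine or a carboxylic acid on this same carbon would give a step beyond the scatter.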